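This account rests on a few compounds, and the source may have more. Where it says the series, first, only, none or still open, it means among the compounds named here.

Three measured compounds share one core. Compound 1 `Cc1cc(=O)n(-c2ccccc2C(F)(F)F)nc1C(=O)Nc1ccc(Oc2ncnc3ccsc23)cc1` gives 8850 nM in a functional assay on A549 cells (Homo sapiens) for cytotoxicity, read by MTT assay, with a stated time of 72 h; on this read-out higher numbers stand for weaker inhibition and lower numbers for stronger inhibition. Compound 2 `Cc1cc(=O)n(-c2ccc(Br)cc2F)nc1C(=O)Nc1ccc(Oc2ncnc3ccsc23)cc1` gives 7930 nM in this assay, and compound 3 `Cc1cc(=O)n(-c2ccccc2C(F)(F)F)nc1C(=O)Nc1ccc(Oc2ncnc3sccc23)cc1` gives 19900 nM in this assay. Of these three numbers compound 3 stands highest. Its nearest neighbour is compound 1, the move being a 2.2-fold higher number from compound 1 to compound 3 (0.35 log units; beyond the scatter), a modest change beyond the scatter. Compound 2 lies furthest from it, and the two values alone show compound 2 with the lower number.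

Compound 4 `Cc1cc(=O)n(-c2ccc(Br)cc2F)nc1C(=O)Nc1ccc(Oc2ncnc3sccc23)cc1` differs from compound 3 by 4-bromo-2-fluorophenyl in place of 2-(trifluoromethyl)phenyl on an aromatic nitrogen. Going by the values given here, one measured step bears directly on this change, since the same pair of groups was exchanged on the same aromatic nitrogen going from compound 1 to compound 2, and that move gave a 1.1-fold lower number from compound 1 to compound 2 (0.05 log units; within the scatter). On this single precedent no step beyond the scatter is expected in this assay for the same exchange. The expected step is therefore a 1.1-fold lower number from compound 3 to compound 4 (0.04 log units; within the scatter). Compound 4 is estimated at 18000 nM, with a range from 9000 nM to 36000 nM.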

Compound 4, half-maximal inhibitory concentration: 12800 nM
The estimate for compound 4 lay 1.4-fold (0.15 log units) above the measured number, within the range that was stated.
By their numbers in this assay, from the lowest: compounds 2, 1, 4 and 3 (each within the scatter of the next, the first and the last beyond it).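

On a second core, the exchange of 2-(trifluoromethyl)phenyl for 4-bromo-2-fluorophenyl on the aromatic nitrogen again stays within the scatter, with a 1.6-fold lower number from compound 3 to compound 4 (0.19 log units; within the scatter), and the two readings agree: the same change on two cores in this assay, a 1.1-fold lower number (0.05 log units; within the scatter) from compound 1 to compound 2 and a 1.6-fold lower number (0.19 log units; within the scatter) from compound 3 to compound 4, 1.4-fold (0.14 log units) apart, within the scatter of two such steps. The exchange of the group on the oxygen, which went beyond the scatter with 2-(trifluoromethyl)phenyl, stays within it with 4-bromo-2-fluorophenyl, with a 1.6-fold higher number from compound 2 to compound 4 (0.21 log units; within the scatter), yet the two steps do not differ beyond the scatter: the same change on two cores in this assay, a 2.2-fold higher number (0.35 log units; beyond the scatter) from compound 1 to compound 3 and a 1.6-fold higher number (0.21 log units; within the scatter) from compound 2 to compound 4, 1.4-fold (0.14 log units) apart, within the scatter of two such steps. Neither exchange therefore shows a dependence on the other place that can be told from the scatter.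

The compounds shown carry only these two substituted phenyl groups on this nitrogen. From the compounds shown here alone, what an unsubstituted phenyl, or a phenyl bearing an amine or a carboxylic acid, would give in this assay remains open.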